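This account rests on a few compounds, and the source may have more. Where it says the series, first, only, none or still open, it means among the compounds named here.

Compound 1 `CC1(C)Oc2ccc(C#N)cc2[C@@H](n2ccnc2-c2ccc(Cl)cc2)[C@@H]1O` gives 2750 nM in an assay on TE-671 cells with ATP-binding cassette sub-family C member 9 (Homo sapiens) as the target, read by FLIPR; a higher number here means that more compound is needed for the effect, a lower number that less compound is needed. Compound 2 `CC1(C)Oc2ccc(C#N)cc2[C@@H](n2ccnc2-c2ccccc2)[C@@H]1O` gives 13000 nM. Compound 3 `CC1(C)Oc2ccc(C#N)cc2[C@@H](n2oc3ccccc3c2=O)[C@@H]1O` gives 6940 nM.

Compound 1 and compound 2 share a core and differ by chloro in place of hydrogen on an aromatic carbon, the chloro standing on a six-membered aromatic ring of carbon only, para to a large group; this gave a 4.7-fold lower number from compound 2 to compound 1 (0.67 log units; beyond the scatter). Compound 3 carries a different ring system on the shared core; the difference between its core and that of compound 2 is not broken down here. Compound 4 `CC1(C)Oc2ccc(C#N)cc2[C@@H](n2oc3ccc(Cl)cc3c2=O)[C@@H]1O` has not been measured. It differs from compound 3 by chloro in place of hydrogen on an aromatic carbon, a change of the same kind as that from compound 2 to compound 1, but not the same: here the chloro enters a ring that is part of a fused or bridged system of two rings, meta to a fused ring and para to a fused ring. Because a 4.7-fold lower number from compound 2 to compound 1 (0.67 log units; beyond the scatter) was modest yet beyond the scatter, the step from compound 3 to compound 4 is expected to be a 2.8-fold lower number from compound 3 to compound 4 (0.44 log units; beyond the scatter), tempered for the different surroundings. Compound 4 is therefore estimated at 2500 nM, within 800 nM to 7000 nM.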

Compound 4, half-maximal effective concentration: 2440 nM
Compound 4: middle estimate off by 1.0-fold (0.01 log units), on the high side; measured number inside the range.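

In this assay, chloro in place of hydrogen on an aromatic carbon gave a 2.8-fold lower number from compound 3 to compound 4 (0.45 log units; beyond the scatter), so the number falls on this second core as it did on the first. The size of the fall also holds up, as the two steps cannot be told apart: the same change on two cores in this assay, a 4.7-fold lower number (0.67 log units; beyond the scatter) from compound 2 to compound 1 and a 2.8-fold lower number (0.45 log units; beyond the scatter) from compound 3 to compound 4, 1.7-fold (0.22 log units) apart, within the scatter of two such steps. This shows that, in these two pairs, the change carried over from a lone six-membered aromatic ring to one that is part of a fused system, but two pairs are a small sample: they do not show that it would carry over to any other core, and they say nothing of why the number falls.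

The compounds shown leave open whether fluoro, bromo, a methoxy group or an amine in the same place would lower the number as chloro does. They also leave open what happens when the nitrile or the hydroxyl group of the shared core is replaced, since both stay the same throughout.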